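A few compounds are considered here, and "the series" means these few. Any claim that something is new, unique, unknown or untested is made for them only; others in the source may bear on it.

Compound 3 `CCc1nc2nc(-c3ccccc3)cc(C(F)(F)F)c2c(=O)n1Cc1cn(CCC(F)(F)C(F)(F)C(F)(F)C(F)(F)C(F)(F)C(F)(F)C(F)(F)C(F)(F)F)nn1` stands at the edge of what a functional assay on COLO 205 cells (Homo sapiens) for cytotoxicity, read by MTT assay, with a stated time of 24 h (a higher number here means a weaker inhibitor, a lower number a stronger inhibitor), can report. In this assay compound 3 gives > 200 ug/mL, which is a limit of the assay rather than a number. For the measured compounds named here, compound 1 `O=c1c2c(C(F)(F)F)cc(-c3ccccc3)nc2ncn1Cc1cn(CCC(F)(F)C(F)(F)C(F)(F)C(F)(F)C(F)(F)C(F)(F)C(F)(F)C(F)(F)F)nn1` carries hydrogen where compound 3 carries ethyl; in this assay compound 1 gives 163 ug/mL, the only plain number among the three. Compound 2 `Cc1nc2nc(-c3ccccc3)cc(C(F)(F)F)c2c(=O)n1Cc1cn(CCC(F)(F)C(F)(F)C(F)(F)C(F)(F)C(F)(F)C(F)(F)C(F)(F)C(F)(F)F)nn1` gives > 200 ug/mL in this assay, again a limit. Two of the three values shown thus sit at the same ceiling (the limit of > 200 ug/mL in this assay, at which 2 of the 3 values shown sit).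

Compound 4 `CC(C)c1nc2nc(-c3ccccc3)cc(C(F)(F)F)c2c(=O)n1Cc1cn(CCC(F)(F)C(F)(F)C(F)(F)C(F)(F)C(F)(F)C(F)(F)C(F)(F)C(F)(F)F)nn1` differs from compound 3 by methyl in place of hydrogen on a saturated chain carbon bound to an aromatic carbon and a saturated chain carbon. Going by the values given here, three measured steps bear on this change. The step of an at least 1.2-fold higher number from compound 1 to compound 2 (0.08 log units; that floor lies within the scatter) and the step of an at least 1.2-fold higher number from compound 1 to compound 3 (0.08 log units; that floor lies within the scatter) both grow the same group from hydrogen and both carry the value up to the limit. The step that the two limits leave unreadable from compound 2 to compound 3 joins two limits and cannot be read. On the strength of an at least 1.2-fold higher number from compound 1 to compound 3 (0.08 log units; that floor lies within the scatter), adding one more carbon is expected to leave compound 4 at or beyond that ceiling, an expected step that the limit leaves unreadable from compound 3 to compound 4 that the assay will most likely not resolve into a number. Compound 4 is estimated at 250 ug/mL, with a range from 150 ug/mL to 450 ug/mL.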

Compound 4, half-maximal inhibitory concentration: > 200 ug/mL
Compound 4: a limit, no number; the forecaster's own chance of this, stated with the estimate: 80%; the middle value lies beyond the limit too.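

In this assay, going from ethyl to isopropyl adds a branch to the group on this aromatic carbon, and compound 4 still yields only a limit, so a branched group now joins the straight methyl and ethyl groups without producing a number. The only step that can be read is an at least 1.2-fold higher number from compound 1 to compound 4 (0.08 log units; that floor lies within the scatter), and since that floor lies within the usual scatter, even this change is not shown to do more than ordinary repeat measurements might. The steps to compound 4 from compound 2 and from compound 3 cannot be read, and the ceiling has become the most common result in this small set: the limit of > 200 ug/mL in this assay, at which 3 of the 4 values shown sit.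

Hydrogen remains the only group here that gives a plain number, with compound 1 at 163 ug/mL, so the compounds shown cannot tell how far methyl, ethyl and isopropyl really lie from hydrogen, or from one another. Also open, going by these compounds, is whether an amine, a hydroxyl group or a carboxylic acid on this same aromatic carbon would bring the value back within the range of this assay.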